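A few compounds are considered here, and "the series" means these few. Any claim that something is new, unique, unknown or untested is made for them only; others in the source may bear on it.

Compound 1 `Cc1cc(-c2ccc(C#N)c(F)c2)ccc1Oc1ccnc(Nc2ccc(C#N)cc2)n1`: in a functional assay on MT4 cells (Homo sapiens) for cytotoxicity, read by MTT assay, with a stated time of 5 days (a lower number here means that less compound is tolerated, a higher number that more compound is tolerated), compound 1 gives > 296000 nM, which is a limit of the assay rather than a number.
Compound 2 `N#Cc1ccc(Nc2nccc(Oc3ccc(-c4ccc(C#N)cc4)c(F)c3)n2)cc1`: in this assay compound 2 gives > 307000 nM, again only a limit.
Compound 3 `N#Cc1ccc(Nc2nccc(Oc3ccc(-c4ccc(C#N)cc4)cc3C(F)(F)F)n2)cc1`: in this assay compound 3 gives > 273000 nM, again only a limit.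

Compound 3 therefore stands at the limit of > 273000 nM in this assay, at which 1 of the 3 values shown sits. Compound 1 and compound 2 likewise reach only limits, so none of the three shows a real number, and no order among them can be read.

Compound 4 `N#Cc1ccc(Nc2nccc(Oc3ccc(-c4ccc(C#N)cc4)cc3Cl)n2)cc1` has not yet been measured. It differs from compound 3 by chloro in place of trifluoromethyl on an aromatic carbon. For the measured compounds named here, no pair of measured compounds shares this particular change, so there is no measured step to lean on. The three measured compounds all sit at limits, and the change is a small one on the shared core, so the expected step is none beyond the scatter, most likely ending at a limit once more.

Compound 4 is expected to give 280000 nM, with a range from 120000 nM to 500000 nM. The step this estimate means, a step that the limit leaves unreadable from compound 3 to compound 4, is expected to stay within the scatter.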

Compound 4, half-maximal cytotoxic concentration: > 295000 nM
Compound 4 was reported as a limit (the forecaster's own chance of this, stated with the estimate: 85%); middle value at least 1.0-fold (0.02 log units) away from the limit.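

For the compounds shown here, compound 3 and compound 4 both reach only limits in this assay, so the change from trifluoromethyl to chloro gives no step that can be read. The compounds shown leave open at what concentration any of them becomes toxic to the cells, and whether that swap changes it.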